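The compounds below may be only part of what the source reports. "The series", "measured", "known", "first", "only" and "open" are said of these compounds alone.

Working notes on the series in a functional assay on CCRF-CEM cells (Homo sapiens) for cytotoxicity; on this read-out higher numbers stand for lower toxicity in this test and lower numbers for higher toxicity in this test. Compound 3 `CCCOCN1c2ccccc2C(=O)NS1(=O)=O` gives only a limit of the assay, > 200 ug/mL. Compound 2 `CC(=O)OCCOCN1c2ccccc2C(=O)NS1(=O)=O` likewise gives only a limit, > 200 ug/mL. Among the measured compounds shown here, the single measured step, a step that the two limits leave unreadable from compound 2 to compound 3, is thus not readable, as the limit of > 200 ug/mL in this assay, at which 2 of the 3 values shown sit, shows. Compound 1 `O=C1c2ccccc2N(COCc2ccccc2)S(=O)(=O)N1Cc1ccccc1` gives 25 ug/mL in this assay. For the measured compounds named here, compound 1 carries an extra benzyl group that compound 3 and compound 4 lack, so no single step links it to either. Compound 4 `O=C1NS(=O)(=O)N(COCc2ccccc2)c2ccccc21` differs from compound 3 by phenyl in place of ethyl on a saturated chain carbon bound to an oxygen on a saturated carbon. Going by the values given here, no measured step bears on this change; the only numeric value in the set is that of compound 1. The expected value for compound 4 in this assay is 100 ug/mL, with a range of 30 ug/mL to 250 ug/mL. The expected step is an at least 2.0-fold lower number from compound 3 to compound 4 (0.30 log units; that floor lies within the scatter), and a limit remains possible.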

Compound 4, half-maximal cytotoxic concentration: > 200 ug/mL
Compound 4: no number, only a limit; the forecaster's own chance of this, stated with the estimate: 45%; middle value at least 2.0-fold (0.30 log units) away from the limit.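

In this assay, among the compounds shown here, the new compound gives the first readable step, and it lies on the amide-type nitrogen in a ring rather than on the side chain: hydrogen in place of benzyl gives an at least 8.0-fold higher number from compound 1 to compound 4 (0.90 log units; beyond the scatter). On the side chain, phenyl in place of ethyl or acetoxymethyl shows no size, as the steps from compound 3 to compound 4 and from compound 2 to compound 4 cannot be read; what stands in the way is: the limit of > 200 ug/mL in this assay, at which 3 of the 4 values shown sit.

On these data alone, whether a smaller group such as methyl or a longer chain ending in an amine on that nitrogen would give a similar step stays open. So does whether benzyl there has the same effect with the propyl or acetoxyethyl side chains.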